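This account rests on a few compounds, and the source may have more. Where it says the series, first, only, none or still open, it means among the compounds named here.

The three measured compounds and their values:

Compound 1, `ClCc1ccc(Cn2cnc3c(Cl)ncnc32)cc1`: 1230 nM
Compound 2, `ClCc1cccc(Cn2cnc3ncnc(Cl)c32)c1`: 2180 nM
Compound 3, `ClCc1ccc(Cn2cnc3c(Cl)nc(Cl)nc32)cc1`: 2040 nM

All three were tested in a functional assay on UACC-62 cells (Homo sapiens) for cytotoxicity, read by sulforhodamine B assay, with a stated time of 48 h; a lower number here means a stronger inhibitor of growth, a higher number a weaker inhibitor of growth. Compound 1 and compound 3 share a core and differ in one place: chloro in place of hydrogen on an aromatic carbon. That single change gave a 1.7-fold higher number from compound 1 to compound 3 (0.22 log units; within the scatter), so the two compounds cannot be told apart with confidence. Compound 2 is built from the same atoms as compound 1, joined differently; the difference between the two cores is not broken down here. In this assay compound 2 gives 2180 nM, and compound 3 gives 2040 nM, values that lie close together.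

Compound 4, `ClCc1cccc(Cn2cnc3nc(Cl)nc(Cl)c32)c1`, has not yet been measured. It stands to compound 2 as compound 3 stands to compound 1: chloro in place of hydrogen on an aromatic carbon. The surroundings of the place are described in the same words in both cases, so this is the same change made on the core of compound 2 rather than on the core of compound 1.

Among the measured compounds shown here, the one measured example of this change is the step from compound 1 to compound 3, which stayed within the scatter. The expectation for compound 4 is therefore a step of about a 1.7-fold higher number from compound 2 to compound 4 (0.22 log units; within the scatter), resting on a 1.7-fold higher number from compound 1 to compound 3 (0.22 log units; within the scatter). On that basis compound 4 is estimated at 3600 nM, with a likely range from 1800 nM to 7500 nM.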

Compound 4, concentration for 50% growth inhibition: 1020 nM
For compound 4 the middle estimate is 3.5-fold (0.55 log units) above the measured one, outside the stated range (below it).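

In this assay, chloro in place of hydrogen on an aromatic carbon gave a 2.1-fold lower number from compound 2 to compound 4 (0.33 log units; beyond the scatter), a modest step but one that can be read. Set beside the earlier case, the same change did not carry over from one core to the other: the same change on two cores in this assay, a 1.7-fold higher number (0.22 log units; within the scatter) from compound 1 to compound 3 and a 2.1-fold lower number (0.33 log units; beyond the scatter) from compound 2 to compound 4, 3.5-fold (0.55 log units) apart, beyond the scatter of two such steps So the step seen on the core of compound 1 was a poor guide to the step on the core of compound 2, but this rests on only two pairs of compounds and does not show why the two cores part ways or what the change would do on a third core.

The compounds shown leave open whether another group on that same aromatic carbon, such as an amine, a methoxy group or a longer chain, would also give different steps on the two cores. They also leave open whether growth inhibition would survive swapping the chloromethyl group for a plain methyl or a hydroxymethyl group on either core.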